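A few compounds are considered here, and "the series" means these few. Any claim that something is new, unique, unknown or untested is made for them only; others in the source may bear on it.

Working notes on the series. In a functional assay on the whole organism (B cells) with Mus musculus as the target (a higher number here means a larger maximal response, a lower number a smaller maximal response), compound 3 `COc1ccc(Cn2c(=O)n(C3OC(CO)[C@@H](O)[C@H]3O)c3nc(N)nc(O)c32)cc1` gives 44%, the highest of the three numbers in hand; compound 1 `C=CCn1c(=O)n(C2CCC(CO)C2)c2nc(N)nc(O)c21` gives 26% and compound 2 `C=CCn1c(=O)n([C@@H]2O[C@H](CO)[C@H]3OC(C)(CCC(=O)NC)O[C@H]32)c2nc(N)nc(O)c21` gives 9%, both beyond the scatter below it. Compound 4 `CCCCn1c(=O)n(C2OC(CO)[C@@H](O)[C@H]2O)c2nc(N)nc(O)c21` is not yet measured. It differs from compound 3 in one place: propyl in place of 4-methoxyphenyl on a saturated chain carbon bound to an aromatic nitrogen. For the measured compounds named here, no step between measured pairs that differ in a single place is available, so the size of the change can only be expected, not derived. Compound 1 and compound 2, which carry a short chain on the same aromatic nitrogen, sit well below compound 3, so a decrease beyond the scatter is expected for compound 4 in this assay, a number 17 percentage points lower from compound 3 to compound 4 (beyond the scatter). The estimate for compound 4 is 27%, expected to fall between 12% and 44%.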

Compound 4, largest response reached (reported as maximal response), in percent of the reference or control that the assay uses: 86%
Beside the measured number, compound 4's estimate is 59 percentage points below it; measured number above the stated range.
By their numbers in this assay, from the lowest: compound 2; then compound 1; then compound 3; then compound 4.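

For the compounds shown here, the first step that can be read at this position is propyl in place of 4-methoxyphenyl, on a saturated chain carbon bound to an aromatic nitrogen, and in this assay it brings a number 42 percentage points higher from compound 3 to compound 4 (beyond the scatter) on the shared core. A large response at this position therefore does not require the aromatic ring or its methoxy group. No available evidence accounts for the gain.

Whether the gain comes from losing the ring or the methoxy group stays open, since unsubstituted benzyl is not among the compounds shown. From the compounds shown here alone, how a longer chain such as hexyl, or a butyl chain ending in an amine, would read also remains open.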